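The source may report more compounds than this note shows. Statements on the series, on what has been measured and on what is new or still open speak of the compounds shown alone.

Working notes on the series: in a functional assay on A549 cells (Homo sapiens) for cytotoxicity, read by sulforhodamine B assay, with a stated time of 48 h (on this read-out higher numbers stand for weaker inhibition and lower numbers for stronger inhibition), compound 1 `O=C(/C=C/c1ccc(Br)cc1)c1cccc(-c2cccc(F)c2)c1` gives 19800 nM, the higher of the two numbers so far, while compound 2 `O=C(/C=C/c1cccc(-c2ccc(F)cc2)c1)c1ccc(O)cc1` gives 8360 nM. Compound 3 `COc1ccc(/C=C/C(=O)c2cccc(-c3cccc(F)c3)c2)cc1` has methoxy in place of bromo on an aromatic carbon, para to a large group: methoxy in place of bromo on an aromatic carbon. Among the measured compounds shown here, no measured pair shows this change, and the data offer no direct guide to its size. A small move toward lower numbers in this assay, not beyond the scatter, is expected as the estimated 1.7-fold lower number from compound 1 to compound 3 (0.22 log units; within the scatter). For compound 3 the expected value is 12000 nM, with an estimated range of 5000 nM to 30000 nM.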

Compound 3, half-maximal inhibitory concentration: 2440 nM
Beside the measured number, compound 3's estimate is 4.9-fold (0.69 log units) above it, and the stated range ends above it.
By their numbers in this assay, from the lowest: compound 3; then compound 2; then compound 1.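

In this assay the swap of bromo for methoxy, para to a large group, gives an 8.1-fold lower number from compound 1 to compound 3 (0.91 log units; beyond the scatter) and so shows that this position responds to the change, beyond the scatter. Among the compounds shown here, this is the first step that differs in one place. Nothing measured here accounts for the size of the step.

Open, from the compounds shown here alone, is where an amine or a longer chain such as ethoxy would fall at this position. Also open, going by these compounds, is whether the same swap gives a step of similar size on a core carrying the fluoro group elsewhere.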